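A few compounds are considered here, and "the series" means these few. Any claim that something is new, unique, unknown or untested is made for them only; others in the source may bear on it.

Measured in a physicochemical assay for lipophilicity, at pH 7.4; on this read-out higher numbers stand for higher lipophilicity and lower numbers for lower lipophilicity:
Compound 1 `COc1ccc(C2CCc3nc[nH]c3C2)cc1`: 2.6
Compound 2 `COCc1ccccc1C1Cc2nccn2C1`: 1.8

Compound 2, at 1.8, holds the lower of the two numbers. Compound 1 stands higher at 2.6, and this gap lies beyond the usual scatter of such measurements.

Compound 3 `N#Cc1ccccc1C1Cc2nccn2C1` has not yet been measured. It differs from compound 2 in one place: cyano in place of methoxymethyl on an aromatic carbon. Going by the values given here, no measured pair of compounds shows a step of this kind, and the expectation rests on the structural change alone. In this assay, no step beyond the scatter is expected, in either direction. The estimated step is a number 0.10 log units lower from compound 2 to compound 3 (within the scatter). In this assay, the estimated value for compound 3 is 1.7, with an expected range of 1.3 to 2.2.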

Compound 3, distribution coefficient: 1.3
Beside the measured number, compound 3's estimate is 0.40 log units above it, and the stated range covers the measured number.
By their numbers in this assay, from the lowest: compound 3; then compound 2; then compound 1.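

In this assay, going by these compounds alone, the swap of methoxymethyl for cyano on this aromatic carbon gives a number 0.50 log units lower from compound 2 to compound 3 (beyond the scatter) and so provides the first step here that can be tied to one place, since compound 1 differs from compound 2 in more than one. This step lies beyond the scatter even though the counts of hydrogen-bond donors and acceptors stay the same and neither group carries a net charge. Nothing available explains the direction or the size of this step.

This single pair cannot show whether the same change would give a similar step on another core, such as that of compound 1. As far as these compounds go, how the read-out of this assay would respond to an amine, a carboxylic acid or a longer ether chain on this aromatic carbon also remains open.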